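The compounds below may be only part of what the source reports. "The series", "measured", "known", "first", "only" and "open" are said of these compounds alone.

Compound 1 `Cn1c(-c2ccccc2F)cnc1NC(=O)c1ccc(F)cc1` was examined in a toxicity assay on THP-1 cells (Homo sapiens) for inhibition; a higher number here means that more compound is tolerated, a lower number that less compound is tolerated. In this assay compound 1 gives > 100000 nM, which is a limit of the assay rather than a number. Compound 2 `COc1ccccc1-c1cnc(NC(=O)c2ncc[nH]2)n1C` was run in the same way. In this assay compound 2 gives > 50000 nM, again a limit of the assay and not a number. Where compound 1 stands can thus only be described as the limit of > 100000 nM in this assay, at which 1 of the 2 values shown sits; for compound 2 the corresponding description is the limit of > 50000 nM in this assay, at which 1 of the 2 values shown sits. With both values sitting at limits, neither compound can be placed relative to the other.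

Compound 3 `Cn1c(-c2cccc(Br)c2)cnc1NC(=O)c1ccc(F)cc1` has not yet been measured in this assay. It differs from compound 1 in one place: 3-bromophenyl in place of 2-fluorophenyl on an aromatic carbon. For the measured compounds named here, no step between measured compounds bears on this change, so the measured pair gives no direction for it. The expectation is that the step of an at least 1.2-fold lower number from compound 1 to compound 3 (0.09 log units; that floor lies within the scatter) amounts to none beyond the scatter, and that compound 3 will most likely also be reported as a limit. Compound 3 is estimated at 80000 nM, with a range from 25000 nM to 200000 nM.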

Compound 3, half-maximal cytotoxic concentration: > 50000 nM
Compound 3: no number, only a limit (the forecaster's own chance of this, stated with the estimate: 70%); the middle value does not contradict the limit.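

Compound 1 and compound 3 are both reported in this assay only as limits of the assay, and the step between these two compounds cannot be read. The compounds shown leave open whether 3-bromophenyl in place of 2-fluorophenyl changes the tolerated concentration at all and, if it does, in which direction.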